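This account rests on a few compounds, and the source may have more. Where it says the series, first, only, none or still open, it means among the compounds named here.

Working notes on the series.

Three analogues of one core have been run in an assay on microsomes from liver for inhibition of sterol O-acyltransferase 1 (Rattus norvegicus); on this read-out higher numbers stand for weaker inhibition and lower numbers for stronger inhibition. Compound 1 `CC(C)n1nc(-c2ccccc2)c(-c2ccccc2)cc1=O` gives 152000 nM in this assay. Compound 2 `CCCCCCCn1nc(-c2ccccc2)c(-c2ccccc2)cc1=O` gives 86000 nM, and the step of a 1.8-fold lower number from compound 1 to compound 2 (0.25 log units; within the scatter). Compound 3 `O=c1cc(-c2ccccc2)c(-c2ccccc2)nn1C1CCCC1` gives 119000 nM, and the step of a 1.3-fold lower number from compound 1 to compound 3 (0.11 log units; within the scatter). Between the two larger groups the step of a 1.4-fold higher number from compound 2 to compound 3 (0.14 log units; within the scatter). Compound 3 therefore holds the second highest of the three numbers, nearest to compound 1 and furthest from compound 2, with neither gap beyond the scatter.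

Compound 4 `O=C(O)CCCCCCn1nc(-c2ccccc2)c(-c2ccccc2)cc1=O` is not yet measured. From compound 3 it differs in one place: 6-carboxyhexyl in place of cyclopentyl on an aromatic nitrogen. Within the data shown here, the steps that bear on this are the three exchanges of the group on the aromatic nitrogen, all of them within the scatter; the closest in kind is the seven-carbon chain of compound 2, which gives 86000 nM. Among the measured compounds shown here, no measured step tests a carboxylic acid at the end of such a chain. The expectation is therefore no step beyond the scatter, at most a drift toward the number of compound 2, so the estimated step is a 1.1-fold lower number from compound 3 to compound 4 (0.03 log units; within the scatter). Compound 4 is estimated at 110000 nM, with a range from 40000 nM to 350000 nM, the width allowing for the untested acid.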

Compound 4, half-maximal inhibitory concentration: > 300000 nM
Compound 4: only a limit was reported (the forecaster's own chance of this, stated with the estimate: 25%); middle value at least 2.7-fold (0.43 log units) away from the limit.
By their numbers in this assay, from the lowest: compounds 2, 3 and 1 (each within the scatter of the next). At a limit, above all of these: compound 4.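

The result for compound 4 in this assay is a limit, not a number: the limit of > 300000 nM in this assay, at which 1 of the 4 values shown sits.

Among these compounds, the group on the aromatic nitrogen had so far made no difference beyond the scatter among isopropyl, heptyl and cyclopentyl, but this position does respond to a change: 6-carboxyhexyl in place of cyclopentyl gives an at least 2.5-fold higher number from compound 3 to compound 4 (0.40 log units; beyond the scatter), and carboxy in place of the terminal methyl of the heptyl chain gives an at least 3.4-fold higher number from compound 2 to compound 4 (0.54 log units; beyond the scatter). The second exchange is the sharper test, as it leaves the chain in place and changes only its end, and it shows that the tolerance seen for these three groups does not extend to a chain ending in a carboxylic acid; the exchange from isopropyl reads an at least 1.9-fold higher number from compound 1 to compound 4 (0.29 log units; that floor lies within the scatter), so on its own it does not separate the two groups.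

The compounds shown leave open whether the step belongs to the carboxylic acid itself or to its place at the end of this long chain, which a shorter chain bearing the same acid, the methyl ester, the primary amide or a terminal amine would help to separate. On these data alone, how far compound 4 lies past its limit also remains open.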